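This account rests on a few compounds, and the source may have more. Where it says the series, first, only, none or still open, it means among the compounds named here.

Measured compounds:
Compound 1, `C=CC(=O)Nc1cccc(Nc2ncnc3ccc(-c4ccc(F)nc4)cc23)c1` — in a functional assay on Ramos cells (Homo sapiens) for inhibition, read by MTT assay, with a stated time of 48 h (a lower number here means a stronger inhibitor, a higher number a weaker inhibitor), compound 1 gives "not determined" (no result reported).
Compound 2, `C=CC(=O)Nc1cccc(Nc2ncnc3ccc(-c4cnc5ccccc5c4)cc23)c1` — in this assay compound 2 gives > 50000 nM, which is a limit of the assay rather than a number.
Compound 3, `C=CC(=O)Nc1cccc(Oc2ncnc3ccc(-c4ccc(Cl)nc4)cc23)c1` — in this assay compound 3 gives 10100 nM.

For the measured compounds named here, compound 3 therefore holds the only single number in this assay; beside it stand one limit and one entry without a result. The limit for compound 2 is summarised as the limit of > 50000 nM in this assay, at which 1 of the 3 values shown sits. Going by the values given here, no pair of these measured compounds differs in just one place, so no measured step is available to lean on.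

The compound not yet measured is compound 4, `C=CC(=O)Nc1cccc(Oc2ncnc3ccc(-c4cccnc4)cc23)c1`. It differs from compound 3 by hydrogen in place of chloro on an aromatic carbon, or, read one bond further out, 6-chloropyridin-3-yl giving way to pyridin-3-yl.

Among the compounds with values here, with no measured step of this kind, the expectation rests on compound 3 alone. A small step in this assay is expected, most likely toward a weaker inhibitor, though a change within the usual scatter would be no surprise. Compound 4 is estimated at 15000 nM, between 4000 nM and 60000 nM. This estimate implies a step of a 1.5-fold higher number from compound 3 to compound 4 (0.17 log units; within the scatter).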

Compound 4, half-maximal inhibitory concentration: 9400 nM
Compound 4: middle estimate off by 1.6-fold (0.20 log units), on the high side, and the stated range covers the measured number.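

Taking the chloro off the 6-chloropyridin-3-yl group gives the only step that can be read in this assay, and it does not move the read-out beyond the scatter: a 1.1-fold lower number from compound 3 to compound 4 (0.03 log units; within the scatter). On this aromatic carbon, next to the ring nitrogen and para to a large group, chloro and hydrogen therefore cannot be told apart in this assay, so the chloro of compound 3 is not needed to hold the number at the level seen for compound 4. The values shown offer no measured basis for giving a cause to this flat step.

As far as these compounds go, compound 3 and compound 4 show only chloro and hydrogen at this carbon, so it remains open whether a larger or differently built group there, such as an amine, a methoxy group or a morpholine ring, would leave the number just as unmoved. From the compounds shown here alone, it also remains open whether the same exchange of chloro for hydrogen would read the same with the amine link of compound 1 in place of the ether link of compound 4.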